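Fluoro for trifluoromethyl in the urea pair

The compounds below may be only part of what the source reports. "The series", "measured", "known", "first", "only" and "open" are said of these compounds alone.

Three compounds share a core in which a benzimidazole-bearing aniline is joined through a thiourea or urea linker to a benzoyl group carrying a benzyloxy side chain. Compound 1 `Cc1ccc(NC(=S)NC(=O)c2ccc(OCc3ccc(C(F)(F)F)cc3)cc2)cc1-c1nc2ccccc2[nH]1` carries a thiourea linker and a trifluoromethyl on the benzyl ring; in a functional assay on MNK45 cells (Homo sapiens) for inhibition, read by MTT assay, with a stated time of 48 h (a higher number here means a weaker inhibitor, a lower number a stronger inhibitor), compound 1 gives 10200 nM. Compound 2 `Cc1ccc(NC(=S)NC(=O)c2ccc(OCc3ccc(F)cc3)cc2)cc1-c1nc2ccccc2[nH]1` keeps the thiourea but has fluoro in that position, and in this assay compound 2 gives 4220 nM. Compound 3 `Cc1ccc(NC(=O)NC(=O)c2ccc(OCc3ccc(C(F)(F)F)cc3)cc2)cc1-c1nc2ccccc2[nH]1` has a urea linker with the trifluoromethyl, and in this assay compound 3 gives 16800 nM, the highest of the three numbers; its gap to compound 1 lies within the scatter, while compound 2 sits well below it, beyond the scatter.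

Compound 4 `Cc1ccc(NC(=O)NC(=O)c2ccc(OCc3ccc(F)cc3)cc2)cc1-c1nc2ccccc2[nH]1` is the urea counterpart of compound 2. The change from compound 3 is fluoro in place of trifluoromethyl on an aromatic carbon.

Among the compounds with values here, the one measured step that matches this change is a 2.4-fold lower number from compound 1 to compound 2 (0.38 log units; beyond the scatter), made on the thiourea pair. Carrying the same change onto the urea pair, a step of similar size and direction in this assay is expected, though the scatter leaves room for it to be smaller. The expected step is a 2.4-fold lower number from compound 3 to compound 4 (0.38 log units; beyond the scatter). Compound 4 is therefore estimated at 7000 nM, with a range from 3500 nM to 14000 nM.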

Compound 4, half-maximal inhibitory concentration: 240 nM
The estimate for compound 4 lay 29-fold (1.46 log units) above the measured number; measured number outside the range, below it.
By their numbers in this assay, from the lowest: compound 4; then compound 2; then compounds 1 and 3 (each within the scatter of the next).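

In this assay, fluoro in place of trifluoromethyl on this aromatic carbon gives a 70-fold lower number from compound 3 to compound 4 (1.85 log units; beyond the scatter), so on the urea linker this small change at the far end of the benzyl side chain has a large effect. The earlier thiourea pair gave no sign of a step this size, and the two pairs differ only in the linker, so the effect of the change is not fixed but depends on which linker is present: the same change on two cores in this assay, a 2.4-fold lower number (0.38 log units; beyond the scatter) from compound 1 to compound 2 and a 70-fold lower number (1.85 log units; beyond the scatter) from compound 3 to compound 4, 29-fold (1.46 log units) apart, beyond the scatter of two such steps

The linker also reads differently with each group: with trifluoromethyl, compound 1 and compound 3 lie within the scatter of each other, whereas with fluoro, compound 2 gives 4220 nM and compound 4 gives 240 nM.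

The compounds shown carry only trifluoromethyl or fluoro at this position, so they leave open how a chloro, a methoxy or a plain hydrogen would behave there on each linker. On these data alone, whether the large step on the urea linker is special to fluoro or extends to such groups remains open, and a cell read-out of this kind does not show how the difference arises.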